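From compound 2 to compound 4: one more nitrooxy

The source may report more compounds than this note shows. Statements on the series, on what has been measured and on what is new or still open speak of the compounds shown alone.

Measured in an ADME assay on liver (Rattus norvegicus, strain Wistar) for metabolic stability, read by HPLC, tested at 200 uM; a lower number here means that the compound disappears faster, a higher number that the compound lasts longer:
- Compound 1 `Cc1cc(OC(=O)OCCCCC(CO[N+](=O)[O-])O[N+](=O)[O-])n(-c2ccccc2)n1`: < 0.0167 h (a limit)
- Compound 2 `Cc1cc(OC(=O)CCCCCO[N+](=O)[O-])n(-c2ccccc2)n1`: < 0.0167 h (a limit)
- Compound 3 `Cc1cc(OC(=O)c2ccc(CCCO[N+](=O)[O-])cc2)n(-c2ccccc2)n1`: < 0.0167 h (a limit)

Compound 2 has no exact half-life. Its result of < 0.0167 h is a limit of the assay and not a number. The other two measured compounds give no number either, and the record shows (the limit of < 0.0167 h in this assay, at which 3 of the 3 values shown sit).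

Compound 4 `Cc1cc(OC(=O)CCCC(CO[N+](=O)[O-])O[N+](=O)[O-])n(-c2ccccc2)n1` has not yet been measured. It carries nitrooxy in place of hydrogen on a saturated chain carbon bound to two saturated chain carbons.

For the measured compounds named here, no measured step gives the size of such a change. Compound 1 also bears a second nitrooxy group, and its result of < 0.0167 h is likewise a limit. No step beyond the scatter is therefore expected in this assay, in either direction. The estimated change is a number no lower from compound 2 to compound 4 (the limit leaves the size open). For compound 4 the expected half-life is 0.0167 h, with an estimated range of 0.008 h to 0.035 h.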

Compound 4, half-life in the liver assay: < 0.0167 h
Compound 4: only a limit was reported (the forecaster's own chance of this, stated with the estimate: 85%); the middle value sits exactly at the limit.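

In the liver assay compound 4 returned < 0.0167 h which is a limit and not a number. In the liver assay compound 2 returned < 0.0167 h which is likewise a limit. No step can be read between them. The compounds shown leave open how long any of them actually lasts in the liver assay and what the added nitrooxy does there. In a physicochemical assay for metabolic stability, read by HPLC (on this read-out higher numbers stand for a longer-lived compound and lower numbers for a shorter-lived compound), compound 2 gives 31 h and compound 4 gives 10 h which amounts to a 3.1-fold lower number from compound 2 to compound 4 (0.49 log units; beyond the scatter) on that read-out.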